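Swapping Benzyl for Isopropyl on the Shared Core

The compounds below may be only part of what the source reports. "The series", "measured", "known", "first", "only" and "open" are said of these compounds alone.

Measured compounds:
- compound 1 `CC1=C(N2CC2)C(=O)C(C(C)COC(N)=O)=C(N2CC2)C1=O`: 5.31
- compound 2 `CC1=C(N2CC2)C(=O)C(N2CC2)=C(N2CC2)C1=O`: 5.69
- compound 3 `CC1=C(N2CC2)C(=O)C(Cc2ccccc2)=C(N2CC2)C1=O`: 4.26

In a functional assay on L1210 cells (Mus musculus), with a stated time of 1 days (a higher number here means a more potent compound, by a factor of ten per unit of this negative logarithm, a lower number a less potent compound), compound 3 gives 4.26, the lowest of the three numbers. Its nearest neighbour is compound 1, and the step from it, a number 1.05 log units lower from compound 1 to compound 3 (beyond the scatter), lies beyond the scatter; the step from compound 2, a number 1.43 log units lower from compound 2 to compound 3 (beyond the scatter), is larger still. Both steps put a seven-carbon benzyl group on a double-bonded ring carbon in place of a smaller or more polar group, and both cost potency.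

Compound 4 `CC1=C(N2CC2)C(=O)C(C(C)C)=C(N2CC2)C1=O` makes the change (isopropyl in place of benzyl on a double-bonded ring carbon). Among the compounds with values here, no measured step swaps benzyl for a plain alkyl group, so the nearest guide is that the benzyl compound sits well below compound 1, whose side chain is also branched and without a ring. A smaller, ring-free group is therefore expected to recover part of the loss, and the step of a number 0.54 log units higher from compound 3 to compound 4 (beyond the scatter) is estimated to be upward. Compound 4 is expected to give about 4.8 in this assay, in the range 4.2 to 5.4.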

Compound 4, logarithm of the reciprocal of the active concentration, log(1/C): 4.69
Beside the measured number, compound 4's estimate is 0.11 log units above it, within the range that was stated.
By their numbers in this assay, from the lowest: compound 3; then compound 4; then compound 1; then compound 2.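

At this double-bonded ring carbon, replacing benzyl with a plain branched alkyl group gives a number 0.43 log units higher from compound 3 to compound 4 (beyond the scatter) in this assay and so recovers only part of the potency, while the step of a number 1.00 log units lower from compound 2 to compound 4 (beyond the scatter) shows that isopropyl still falls well short of aziridin-1-yl. The carbamoyloxy group on the side chain of compound 1 also matters, as putting hydrogen in its place gives a number 0.62 log units lower from compound 1 to compound 4 (beyond the scatter) and shows that the branched carbon skeleton alone does not match compound 1. Nothing available here explains why these groups differ.

Still open, on these data alone, is whether a hydroxyl group at the end of that branched chain would hold the potency that carbamoyloxy gives. Also open, as far as these compounds go, is how a primary amine or a longer straight alkyl chain at this ring carbon would compare with aziridin-1-yl.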